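The source may hold more compounds than are shown below. What is called first, only, known or untested is meant among the compounds shown, and "the series" means these compounds.

Compounds measured so far:

- compound 1, `Cc1nn([C@H](C)c2ccc(Cl)cc2Cl)c2nc(N3CC[C@H](N4CCCC4)[C@H](C)C3)cnc12`: "not determined" (no result reported) in an assay on CCRF-CEM cells for antagonist activity at C-C chemokine receptor type 4 (Homo sapiens), read by CellTiter-Glo, with stated times of 30 min and 60 min, in the presence of a further agent that is not named here; on this read-out higher numbers stand for weaker inhibition and lower numbers for stronger inhibition
- compound 2, `Cc1nn([C@H](C)c2ccc(Cl)cc2Cl)c2nc(N3CC[C@H](N4CCC[C@H]4CCS(C)(=O)=O)[C@H](C)C3)cnc12`: "not determined" (no result reported) in this assay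
- compound 3, `Cc1nn([C@H](C)c2ccc(Cl)cc2Cl)c2nc(N3CC[C@H](N4CCC[C@H]4CCC#N)[C@H](C)C3)cnc12`: 865 nM

Within the data shown here, compound 3 is the only member of the set with a number in this assay; compounds 1 and 2 carry no result there, so compound 3 cannot be ranked against anything and simply marks the one fixed point of the series.

Compound 4, `Cc1nn([C@H](C)c2ccc(Cl)cc2Cl)c2nc(N3CC[C@H](N4CCCCCC4)[C@H](C)C3)cnc12`, differs from compound 3 in a single place: azepan-1-yl in place of 2-(2-cyanoethyl)pyrrolidin-1-yl on a saturated ring carbon. Among the measured compounds shown here, no step between two measured compounds exists that could calibrate this change, so the direction of the step in this assay is open. The working assumption is that the step from compound 3 to compound 4 stays close to the scatter, leaning if anything towards weaker inhibition, with a wide range to cover the absence of any reference step. The expected step is a 1.7-fold higher number from compound 3 to compound 4 (0.24 log units; within the scatter). On that basis compound 4 is estimated at 1500 nM in this assay, with an expected range from 400 nM to 6000 nM.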

Compound 4, half-maximal inhibitory concentration: 195 nM
For compound 4 the middle estimate is 7.7-fold (0.89 log units) above the measured one; the measured number lies below the stated range.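

At this saturated ring carbon, three ring bonds from the ring nitrogen, the group can be changed with a clear effect in this assay: azepan-1-yl in place of 2-(2-cyanoethyl)pyrrolidin-1-yl gives a 4.4-fold lower number from compound 3 to compound 4 (0.65 log units; beyond the scatter), so the nitrile-bearing chain is not required for a measurable result in this pair. The exchange alters the ring size, the side chain and the defined stereocentre at once, and this single step cannot assign the change to any one of them. Nothing available explains the step.

Steps involving compound 1 and compound 2 cannot be read, so pyrrolidin-1-yl without its chain offers no separate reference. Going by these compounds, whether piperidin-1-yl, morpholin-4-yl or an azepane ring carrying the 2-cyanoethyl chain would follow the same direction remains open.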